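Replacing Cyano with Methylsulfanyl: What Exposure to Expect

The source may hold more compounds than are shown below. What is called first, only, known or untested is meant among the compounds shown, and "the series" means these compounds.

In an ADME assay on the whole organism (Rattus norvegicus) for pharmacokinetics, read by HPLC, at a dose of 3 mg/kg by the oral route (on this read-out higher numbers stand for higher exposure at the dose given and lower numbers for lower exposure), compound 2 (`N#Cc1cc(C(=O)N2CS(=O)(=O)c3ccccc32)cc(Cl)c1O`) gives 3870 nM. It sits within the scatter of compound 3 (`C#Cc1cc(C(=O)N2CS(=O)(=O)c3ccccc32)cc(C#N)c1O`), which gives 4670 nM, the step between them being a 1.2-fold higher number from compound 2 to compound 3 (0.08 log units; within the scatter). Compound 1 (`N#Cc1cc(C(=O)N2CS(=O)(=O)c3ccccc32)cc(C2CC2)c1O`) stands clear of both at 10800 nM.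

Compound 4 (`CSc1cc(C(=O)N2CS(=O)(=O)c3ccccc32)cc(Cl)c1O`) keeps the chloro group of compound 2 but carries methylsulfanyl in place of cyano on an aromatic carbon, ortho to a hydroxy group: methylsulfanyl in place of cyano on an aromatic carbon. Within the data shown here, no measured step speaks directly to this change, since compound 1, compound 2 and compound 3 all retain a nitrile. The available steps instead exchange other groups on an aromatic carbon. Chloro in place of cyclopropyl gave a 2.8-fold lower number from compound 1 to compound 2 (0.45 log units; beyond the scatter), and ethynyl in place of cyclopropyl gave a 2.3-fold lower number from compound 1 to compound 3 (0.36 log units; beyond the scatter). These steps suggest that a single exchange of this kind can be modest in size, but they give only weak guidance on direction. Losing the nitrile is new territory for this set, so a modest fall is tentatively expected, with a wide margin on either side. The estimated change is a 1.8-fold lower number from compound 2 to compound 4 (0.25 log units; within the scatter). For compound 4 the expected value is 2200 nM, with an estimated range of 800 nM to 6000 nM.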

Compound 4, maximal plasma concentration: 12500 nM
For compound 4 the middle estimate is 5.7-fold (0.75 log units) below the measured one; the whole stated range lies below it.
By their numbers in this assay, from the lowest: compounds 2 and 3 (each within the scatter of the next); then compounds 1 and 4 (each within the scatter of the next).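

At this position, ortho to a hydroxy group, the nitrile proves not to be needed for high exposure in this assay: with the chloro group held constant, methylsulfanyl in place of cyano gives a 3.2-fold higher number from compound 2 to compound 4 (0.51 log units; beyond the scatter). Among these compounds, the earlier compounds could not show this, since all of them retain a nitrile, and their only step starting from compound 2 stays within the scatter, whereas this one goes beyond it and shows that exposure responds to the group at this position. Nothing in the data accounts for the rise, as no measurement here bears on why exchanging these two groups raises the maximal plasma concentration.

On these data alone, all of this rests on one pair of compounds, so it remains open whether methylsulfanyl in place of cyano would give a step of similar size and direction with cyclopropyl or ethynyl in place of the chloro group. Also open, as far as these compounds go, is how exposure would respond at this position to other groups, such as methoxy, an amine, or a longer chain like ethylsulfanyl, so the sulfur-bearing group cannot yet be set against any close relative.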